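The compounds below may be only part of what the source reports. "The series", "measured", "known", "first", "only" and "open" are said of these compounds alone.

For the measured compounds named here, compound 3 `CCCNc1nc(-c2ccccc2)nc2c1nnn2Cc1ccccc1` was tested in an assay on isolated protein for binding affinity to adenosine receptor A1 (Bos taurus) (a lower number here means a stronger inhibitor, a higher number a weaker inhibitor), where compound 3 gives 37000000 nM, the highest of the three numbers measured so far. Compound 2 `OCCCNc1nc(-c2ccccc2)nc2c1nnn2Cc1ccccc1` gives 21400000 nM, and compound 1 `CCCCNc1nc(-c2ccccc2)nc2c1nnn2Cc1ccccc1F` gives 4300000 nM; the gap from compound 3 to compound 1 lies beyond the scatter, but those two compounds differ in two places at once. Compound 4 `CCCCNc1nc(-c2ccccc2)nc2c1nnn2Cc1ccccc1` differs from compound 3 by methyl in place of hydrogen on a saturated chain carbon, three bonds along the chain from a nitrogen on an aromatic ring. Going by the values given here, the only single step measured so far on that chain, a 1.7-fold higher number from compound 2 to compound 3 (0.24 log units; within the scatter), stayed within the scatter, so a lengthening of the chain by one carbon is also expected to move this assay little, perhaps slightly downward toward compound 1. Compound 4 is therefore estimated at 15000000 nM, within a range from 4000000 nM to 45000000 nM, which means an expected step of a 2.5-fold lower number from compound 3 to compound 4 (0.39 log units; beyond the scatter).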

Compound 4, inhibition constant: 11000000 nM
Estimate against measurement, compound 4: 1.4-fold (0.13 log units) above; measured number inside the range.
By their numbers in this assay, from the lowest: compound 1; then compounds 4, 2 and 3 (each within the scatter of the next, the first and the last beyond it).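

In this assay the change from propyl to butyl gives a 3.4-fold lower number from compound 3 to compound 4 (0.53 log units; beyond the scatter) and so, unlike the earlier step on this chain, moves the number beyond the scatter, while methyl in place of hydroxy gives a 1.9-fold lower number from compound 2 to compound 4 (0.29 log units; within the scatter) and stays within it. Hydrogen in place of fluoro on an aromatic carbon, now readable as a single change, gives a 2.6-fold higher number from compound 1 to compound 4 (0.41 log units; beyond the scatter) and leaves the fluoro compound with the lower number. No measurement here explains these steps. On these data alone, whether a chain longer than butyl lowers the number further remains open, as does the effect of an amine on this chain or of chloro in place of fluoro.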